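Extending the Benzyl Substituent: From Compound 1 to Compound 3

The source may hold more compounds than are shown below. What is called first, only, known or untested is meant among the compounds shown, and "the series" means these compounds.

Compound 1 `COc1cccc(OC)c1C1CCCC(=O)N1Cc1ccccc1` — 2420 nM
Compound 2 `COc1cccc(OC)c1C1CCCC(=O)N1Cc1ccc(-c2ccccc2)cc1` — 1090 nM

Of the compounds shown here, two sharing the same core have been measured in a functional assay on CHO cells for antagonist activity at Orexin/Hypocretin receptor type 1 (Homo sapiens), read by FLIPR and calcium flux; a higher number here means a weaker inhibitor, a lower number a stronger inhibitor. Compound 1 gives 2420 nM and stands as the higher of the two numbers; its nearest neighbour is compound 2, which gives 1090 nM. Among the measured compounds shown here, the only measured step, a 2.2-fold lower number from compound 1 to compound 2 (0.35 log units; beyond the scatter), comes from placing a phenyl group on the aromatic carbon of the benzyl ring.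

Compound 3 `COc1cccc(OC)c1C1CCCC(=O)N1Cc1cccc(-c2ncccn2)c1` has not yet been measured. It differs from compound 1 by pyrimidin-2-yl in place of hydrogen on an aromatic carbon. The step from compound 1 to compound 2 bears on this change only loosely: it also adds an aromatic ring to the benzyl ring, but a different ring at a different place. Given the modest size of a 2.2-fold lower number from compound 1 to compound 2 (0.35 log units; beyond the scatter), a step of similar or smaller size in the same direction is expected from compound 1 to compound 3, a 1.7-fold lower number from compound 1 to compound 3 (0.24 log units; within the scatter), with a wide band of uncertainty. Compound 3 is therefore estimated at 1400 nM, between 500 nM and 4000 nM.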

Compound 3, half-maximal inhibitory concentration: 14 nM
For compound 3 the middle estimate is 100-fold (2.00 log units) above the measured one, and the stated range ends above it.
By their numbers in this assay, from the lowest: compound 3; then compound 2; then compound 1.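

In this assay, pyrimidin-2-yl on an aromatic carbon, meta to a large group, brings a 170-fold lower number from compound 1 to compound 3 (2.24 log units; beyond the scatter), so this one substitution on the benzyl ring is enough to carry the series from weak to strong inhibition. Among the compounds shown here, the only earlier step, a 2.2-fold lower number from compound 1 to compound 2 (0.35 log units; beyond the scatter), had suggested that adding an aromatic ring to the benzyl ring changes little, and compound 3 shows that this does not hold for every added ring at every place. No measurement shown here explains the size of this step, and the two added rings differ both in their atoms and in where they sit, so the result cannot be assigned to either difference alone.

What the compounds shown leave open is whether the ring nitrogens or the place on the ring account for the result, a question that phenyl or pyridin-2-yl on this same carbon would address. On these data alone, it also remains open whether this carbon can carry something other than an aromatic ring, such as an amine or a carboxylic acid, with a comparable result.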